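A few compounds are considered here, and "the series" means these few. Any claim that something is new, unique, unknown or untested is made for them only; others in the source may bear on it.

Compound 1 `COc1cc(OC)c(-c2coc3cc(OCc4ccc(F)cc4)ccc3c2=O)cc1OC` is the reference point of the pair measured so far; in a functional assay on B16 cells (Mus musculus) for antiproliferative activity, read by MTT assay, with a stated time of 24 h (on this read-out lower numbers stand for stronger inhibition and higher numbers for weaker inhibition), compound 1 gives 1120 nM. Compound 2 `COc1cc(OC)c(-c2coc3cc(OCc4ccc([N+](=O)[O-])cc4)ccc3c2=O)cc1OC` carries nitro in place of fluoro on an aromatic carbon. In this assay compound 2 returns only a limit, > 10000 nM, so its position is known just as a floor, and the comparison with compound 1 reads as an at least 8.9-fold higher number from compound 1 to compound 2 (0.95 log units; beyond the scatter). That step rests on (the limit of > 10000 nM in this assay, at which 1 of the 2 values shown sits), which caps how large it can be counted.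

Compound 3 `COc1cc(OC)c(-c2coc3cc(OCc4ccc(C(F)(F)F)cc4)ccc3c2=O)cc1OC` differs from compound 2 by trifluoromethyl in place of nitro on an aromatic carbon. The only measured step that touches this position is the one from compound 1 to compound 2, where the exchange of fluoro for nitro cost at least the amount given above; trifluoromethyl matches neither of those groups, so the sole guide is that removing nitro undoes the change that produced the limit. On that basis compound 3 is expected to move back toward the number of compound 1, as an at least 4.0-fold lower number from compound 2 to compound 3 (0.60 log units; beyond the scatter), with wide uncertainty because compound 2 offers only a limit. Compound 3 is estimated at 2500 nM, between 700 nM and 10000 nM.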

Compound 3, half-maximal inhibitory concentration: 5400 nM
The estimate for compound 3 lay 2.2-fold (0.33 log units) below the measured number; measured number inside the range.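

In this assay, fluoro stays ahead of trifluoromethyl at this aromatic carbon, at a 4.8-fold higher number from compound 1 to compound 3 (0.68 log units; beyond the scatter), so the loss seen with nitro is not specific to nitro: a second replacement of fluoro also gives a weaker number, though one that can be read as a value. Going by these compounds, compound 2 remains a limit, > 10000 nM, and its true number is unknown. Against nitro, the exchange reads as an at least 1.8-fold lower number from compound 2 to compound 3 (0.26 log units; that floor lies within the scatter), so the data do not establish a real gap between the two replacement groups, and the reading depends on a censored value: the limit of > 10000 nM in this assay, at which 1 of the 3 values shown sits.

With three groups at this aromatic carbon and one of them known only as a limit, the order of nitro and trifluoromethyl remains unsettled, and no trend across substituents can be drawn. On these data alone, it also remains open whether a different kind of group, such as an amine, a carboxylic acid or a chlorine atom, in place of fluoro on this carbon would keep the number of compound 1, 1120 nM, or lose ground as both replacements here do.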